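A few compounds are considered here, and "the series" means these few. Any claim that something is new, unique, unknown or untested is made for them only; others in the source may bear on it.

Series notes, antiproliferative read-out.

Compound 1 `CCOC(=O)N1N=C(c2ccccc2)CC1c1cc(OC)c(OC)c(OC)c1` and compound 2 `CCOC(=O)N1N=C(c2cccc(O)c2)CC1c1cc(OC)c(OC)c(OC)c1` share a core and differ only on one aromatic ring; compound 3 `COC(=O)N1N=C(c2ccccc2)CC1c1ccc(OC)c(O)c1` carries a different core, and compound 4 `COC(=O)N1N=C(c2ccccc2)CC1c1ccc(OC)cc1` is its counterpart, still to be measured.

In a functional assay on A2780 cells (Homo sapiens) for antiproliferative activity, read by MTT assay, with a stated time of 48 h (on this read-out higher numbers stand for weaker inhibition of growth and lower numbers for stronger inhibition of growth), compound 1 gives 6720 nM, compound 2 gives 9750 nM, and compound 3 gives 4960 nM. All three numbers sit within the usual scatter of one another, so no order among them is claimed.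

Among the compounds with values here, the one measured step of the change in question is a 1.5-fold lower number from compound 2 to compound 1 (0.16 log units; within the scatter), with the change being (hydrogen in place of hydroxy on an aromatic carbon). How the core of compound 3 differs from that of compound 2 is not broken down here.

From compound 3 to compound 4 the change is hydrogen in place of hydroxy on an aromatic carbon. The place is not identical to the earlier one: here the carbon is ortho to a methoxy group as well as meta to a large group, so this is the same kind of change rather than the same one.

Expectation for compound 4 rests on the earlier step, a 1.5-fold lower number from compound 2 to compound 1 (0.16 log units; within the scatter), which was within the scatter; a step of similar size, a 1.2-fold lower number from compound 3 to compound 4 (0.09 log units; within the scatter), is therefore expected. Compound 4 is estimated at 4000 nM, with a range of 1800 nM to 9000 nM in this assay.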

Compound 4, concentration for 50% growth inhibition: > 10000 nM
Compound 4 gave a limit, no number (the forecaster's own chance of this, stated with the estimate: 5%); at least 2.5-fold (0.39 log units) between middle value and limit.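

In this assay compound 4 gives > 10000 nM, which is a limit of the assay and not a number. On the core of compound 3, hydrogen in place of hydroxy on an aromatic carbon reads as an at least 2.0-fold higher number from compound 3 to compound 4 (0.30 log units; that floor lies within the scatter), and the step does not carry over unchanged from the core of compound 1: the same change on two cores in this assay, a 1.5-fold lower number (0.16 log units; within the scatter) from compound 2 to compound 1 and an at least 2.0-fold higher number (0.30 log units; that floor lies within the scatter) from compound 3 to compound 4, at least 2.9-fold (0.46 log units) apart, beyond the scatter of two such steps

This shows that the size of the change depends on its setting in these two pairs, but it rests on a single pair per core, the hydroxy stands in a different place in each pair, the true size of the step from the limit remains unknown, and the data do not say which difference between the two settings accounts for the gap.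

Still open, from the compounds shown here alone, is how the change behaves with the hydroxy at the same place on both cores. Also open, going by these compounds, is whether an amine or a fluorine atom in place of the hydroxy on the core of compound 3 would give a value nearer to that of compound 3 or to the limit of compound 4.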